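Swapping the Benzyl Substituent of a Weak Growth Inhibitor

A few compounds are considered here, and "the series" means these few. Any claim that something is new, unique, unknown or untested is made for them only; others in the source may bear on it.

Compound 2 `COc1cccc(OC)c1OCCNCCOc1ccccc1OCc1cccc([N+](=O)[O-])c1` gives 13200 nM in a functional assay on PC-3 cells (Homo sapiens) for cytotoxicity, read by sulforhodamine B assay (a lower number here means a stronger inhibitor of growth, a higher number a weaker inhibitor of growth), the larger of the two numbers in hand, though the nearest, compound 1 `COc1cccc(OC)c1OCCNCCOc1ccccc1OCc1ccccc1C` at 11500 nM, lies within the scatter of it. Compound 3 `COc1cccc(COc2ccccc2OCCNCCOc2c(OC)cccc2OC)c1` differs from compound 2 by methoxy in place of nitro on an aromatic carbon. For the measured compounds named here, the only step bearing on this change, a 1.1-fold higher number from compound 1 to compound 2 (0.06 log units; within the scatter), moved the number by no more than the scatter, so another swap of the group on that ring is expected to leave the result essentially unchanged. Compound 3 is therefore estimated at 12000 nM, between 5000 nM and 30000 nM, which means an expected step of a 1.1-fold lower number from compound 2 to compound 3 (0.04 log units; within the scatter).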

Compound 3, concentration for 50% growth inhibition: 2500 nM
The estimate for compound 3 lay 4.8-fold (0.68 log units) above the measured number; the whole stated range lies above it.
By their numbers in this assay, from the lowest: compound 3; then compounds 1 and 2 (each within the scatter of the next).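

In this assay the group on this aromatic carbon now counts: methoxy in place of nitro gives a 5.3-fold lower number from compound 2 to compound 3 (0.72 log units; beyond the scatter) and 3-methoxyphenyl in place of 2-methylphenyl gives a 4.6-fold lower number from compound 1 to compound 3 (0.66 log units; beyond the scatter) as the second step beyond the scatter. The earlier swap between compound 1 and compound 2 had shown no such movement, so the outcome at this position depends on which group enters. Nothing here accounts for the difference. As far as these compounds go, whether an amine or ethoxy on the same carbon would match methoxy remains open. So does whether methoxy needs to stand meta to a large group.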